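The source may report more compounds than this note shows. Statements on the series, on what has been measured and on what is new or still open speak of the compounds shown alone.

Compound 1 `CCc1ccccc1-c1cc2c(cn1)ncn2-c1ccc(OC(F)F)cc1`: 2900 nM
Compound 2 `Cc1ccc(-c2cc3c(cn2)ncn3-c2ccc(OC(F)F)cc2)c(C)c1`: 180 nM
Compound 3 `Cc1cc(O)ccc1-c1cc2c(cn1)ncn2-c1ccc(OC(F)F)cc1`: 890 nM

All three compounds share one core and differ only in the aromatic ring attached to it. In a functional assay on HL-60 cells (Homo sapiens) for activation, read by flow cytometry, with a stated time of 4 days (on this read-out lower numbers stand for an effect already at smaller amounts and higher numbers for an effect only at larger amounts of compound), compound 3 gives 890 nM, the second highest of the three numbers. Its nearest neighbour is compound 1, with a 3.3-fold lower number from compound 1 to compound 3 (0.51 log units; beyond the scatter); its furthest is compound 2, with a 4.9-fold higher number from compound 2 to compound 3 (0.69 log units; beyond the scatter). The largest step among the measured compounds is a 16-fold lower number from compound 1 to compound 2 (1.21 log units; beyond the scatter).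

Compound 4 `Cc1nc(F)ccc1-c1cc2c(cn1)ncn2-c1ccc(OC(F)F)cc1` has not yet been measured. It differs from compound 3 in one place:

6-fluoro-2-methylpyridin-3-yl in place of 4-hydroxy-2-methylphenyl on an aromatic carbon

The step that bears most directly on this change is a 4.9-fold higher number from compound 2 to compound 3 (0.69 log units; beyond the scatter), where putting a hydroxy in place of a methyl raised the number modestly. Compound 4 again lacks the hydroxy, so part of that loss might be recovered. Within the data shown here, no measured step covers the entry of a ring nitrogen or of a fluorine, so the rest of the change is uncharted. On balance a modest lowering is expected, a 2.2-fold lower number from compound 3 to compound 4 (0.35 log units; beyond the scatter). Compound 4 is therefore estimated to give 400 nM, with a plausible range from 100 nM to 1600 nM.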

Compound 4, half-maximal effective concentration: 2000 nM
For compound 4 the middle estimate is 5.0-fold (0.70 log units) below the measured one; the whole stated range lies below it.
By their numbers in this assay, from the lowest: compound 2; then compound 3; then compounds 4 and 1 (each within the scatter of the next).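

Losing the hydroxy does not by itself bring back the low number of compound 2: in this assay the 6-fluoro-2-methylpyridin-3-yl ring gives a 2.2-fold higher number from compound 3 to compound 4 (0.35 log units; beyond the scatter) and also an 11-fold higher number from compound 2 to compound 4 (1.05 log units; beyond the scatter), so the 2,4-dimethylphenyl ring remains well ahead of this replacement, which likewise has no hydrogen-bond donor. The comparison with the 2-ethylphenyl ring gives a 1.5-fold lower number from compound 1 to compound 4 (0.16 log units; within the scatter), which places two quite different rings at the same level and shows that this position can reach the high end of the series through more than one change. Nothing at hand explains these differences.

From the compounds shown here alone, the ring nitrogen and the fluorine enter together in compound 4, so it stays open how much of the rise belongs to each, and a 2-methylpyridin-3-yl ring without the fluorine or a 4-fluoro-2-methylphenyl ring would be needed to separate them. Going by these compounds, it is also open how a 2-methylphenyl ring would read with a chlorine, a methoxy or an amine in the place held by the hydroxy of compound 3.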